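A few compounds are considered here, and "the series" means these few. Any claim that something is new, unique, unknown or untested is made for them only; others in the source may bear on it.

Working notes on the series. Compound 2 `O=C1N/C(=N\Cc2ccc(Cl)cc2)S/C1=C1/CCNC(=O)c2[nH]ccc21` in a functional assay on SK-MEL-28 cells (Homo sapiens) for inhibition, read by MTT assay, with a stated time of 48 h (a lower number here means a stronger inhibitor, a higher number a weaker inhibitor), gives > 100000 nM, a limit of the assay. Compound 1 `O=C1N/C(=N\Cc2ccc(C(F)(F)F)cc2)S/C1=C1/CCNC(=O)c2[nH]ccc21` gives > 100000 nM, likewise a limit. Compound 3 `O=C1N/C(=N\Cc2cccc(Cl)c2)S/C1=C1/CCNC(=O)c2[nH]ccc21` gives 34700 nM, the only plain number shown. The step that the two limits leave unreadable from compound 1 to compound 2 and the step of an at least 2.8-fold lower number from compound 2 to compound 3 (0.45 log units; beyond the scatter) are the two measured comparisons; of these, only the first changes the same position as the step now followed, and it is unreadable because of the limit of > 100000 nM in this assay, at which 2 of the 3 values shown sit. Compound 4 `O=C1N/C(=N\Cc2ccc(F)cc2)S/C1=C1/CCNC(=O)c2[nH]ccc21` differs from compound 2 by fluoro in place of chloro on an aromatic carbon. Going by the values given here, no measured step of readable size bears on this change, so no shift beyond the scatter is expected, and compound 2 is itself a limit. For compound 4 the estimate is 150000 nM (range 40000 nM to 600000 nM), an expected step that the limit leaves unreadable from compound 2 to compound 4.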

Compound 4, half-maximal inhibitory concentration: 11200 nM
Compound 4: middle estimate off by 13-fold (1.13 log units), on the high side; measured number below the stated range.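

In this assay the group on this aromatic carbon now has a readable effect: fluoro in place of chloro gives an at least 8.9-fold lower number from compound 2 to compound 4 (0.95 log units; beyond the scatter) and fluoro in place of trifluoromethyl gives an at least 8.9-fold lower number from compound 1 to compound 4 (0.95 log units; beyond the scatter). The 4-fluorophenyl also stands ahead of the 3-chlorophenyl, with a 3.1-fold lower number from compound 3 to compound 4 (0.49 log units; beyond the scatter).

From the compounds shown here alone, whether a methoxy group or an amine at this place would give a lower number still remains open. Going by these compounds, the full size of the two steps starting from limits also stays open because those values end at a limit: the limit of > 100000 nM in this assay, at which 2 of the 4 values shown sit.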